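This account rests on a few compounds, and the source may have more. Where it says the series, first, only, none or still open, it means among the compounds named here.

Series notes. Compound 1 `O=c1c(-c2ccc(O)cc2)coc2cc(OCCCCCCBr)ccc12` and compound 2 `O=c1c(-c2ccc(O)cc2)coc2cc(OCCC3OCCCO3)ccc12` share one core and differ only in the group on a saturated chain carbon two bonds along the chain from an oxygen on an aromatic ring. In a functional assay on mitochondria (Cricetulus griseus) for inhibition of Monoamine oxidase (Homo sapiens), tested at 3 uM (a lower number here means a weaker effect, a higher number a stronger effect of the compound at the concentration tested), compound 1 gives 88.5%, and compound 2 gives 75.3%. Going by the values given here, the single step so far, a number 13.2 percentage points lower from compound 1 to compound 2 (beyond the scatter), leaves compound 2 with the lowest of the two numbers; compound 1 is the nearest and stands higher by an amount beyond the scatter. Compound 3 `C=CCOc1ccc2c(=O)c(-c3ccc(O)cc3)coc2c1` is not yet measured; its change from compound 2 is a group of 2 heavy atoms (2 carbon; no ring) in place of a group of 7 heavy atoms (5 carbon, 2 oxygen; one six-membered non-aromatic ring with 2 hetero atoms), on a saturated chain carbon bound to an oxygen on an aromatic ring. Among the compounds with values here, only that one step bears on it: the ring whose entry accompanied the lower number now leaves again, so some return toward the level of compound 1 is expected, though the entering vinyl is not the bromine-bearing chain and no measured step tests it directly. A step of a number 5.7 percentage points higher from compound 2 to compound 3 (within the scatter) is estimated, a moderate rise. Compound 3 is therefore expected to reach about 81%, with a range from 62% to 94%.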

Compound 3, a percentage reported as inhibition, at one concentration (the size of the read-out at that concentration, not a potency): 89.3%
The estimate for compound 3 lay 8.3 percentage points below the measured number; low and high end bracket the measured number.
By their numbers in this assay, from the lowest: compound 2; then compounds 1 and 3 (each within the scatter of the next).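

The swap of the ring-bearing group for vinyl in this assay gives a number 14 percentage points higher from compound 2 to compound 3 (beyond the scatter) and so shows that the lower number of compound 2 is not shared by a much shorter group at this place. The comparison of vinyl with 5-bromopentyl gives a number 0.8 percentage points higher from compound 1 to compound 3 (within the scatter) and so leaves these two groups unseparated in this read-out, despite their difference in size, with only the group carrying the six-membered non-aromatic ring standing apart among the three compounds. No measured evidence bears on the reason for this result.

Going by these compounds, whether the lower number follows the ring itself or its two oxygens remains open, as a cyclohexyl group at the chain end would test. On these data alone, an amine or a carboxylic acid at the end of the chain also remains untested at this place.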